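Ortho substituent on the anilino ring: methyl next

The compounds below may be only part of what the source reports. "The series", "measured", "known", "first", "only" and "open" are said of these compounds alone.

The series shares one core, varied only on the anilino ring. Compound 1 `CC(C)c1ccc(-c2nc(SCc3cn(CC(=O)NC(=O)Nc4ccccn4)nn3)nc(Nc3ccccc3Cl)c2C#N)cc1` carries chloro there and gives 6790 nM in a functional assay on B16-F10 cells (Mus musculus) for inhibition, read by MTT assay, with a stated time of 72 h; a lower number here means a stronger inhibitor, a higher number a weaker inhibitor. Compound 2 `CC(C)c1ccc(-c2nc(SCc3cn(CC(=O)NC(=O)Nc4ccccn4)nn3)nc(Nc3ccccc3F)c2C#N)cc1` carries fluoro and gives 8380 nM. Compound 3 `CC(C)c1ccc(-c2nc(SCc3cn(CC(=O)NC(=O)Nc4ccccn4)nn3)nc(Nc3ccccc3)c2C#N)cc1` carries no substituent on that ring and gives 14300 nM, the highest of the three numbers; its distance from compound 2 is within the scatter, a 1.7-fold higher number from compound 2 to compound 3 (0.23 log units; within the scatter), while its distance from compound 1 is beyond it, a 2.1-fold higher number from compound 1 to compound 3 (0.32 log units; beyond the scatter).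

Compound 4 `Cc1ccccc1Nc1nc(SCc2cn(CC(=O)NC(=O)Nc3ccccn3)nn2)nc(-c2ccc(C(C)C)cc2)c1C#N` is the next member: methyl in place of hydrogen on an aromatic carbon, placed on an aromatic carbon of a six-membered aromatic ring of carbon only, ortho to a large group. The two measured steps that bear on this change are the removals of chloro and fluoro from the same position, a 2.1-fold higher number from compound 1 to compound 3 (0.32 log units; beyond the scatter) and a 1.7-fold higher number from compound 2 to compound 3 (0.23 log units; within the scatter); both point the same way, a modest rise in the number when the substituent is taken away. Restoring a substituent, here methyl, is therefore expected to move the number of compound 3 down by a modest step, roughly the size seen with chloro, though the data hold no methyl analogue to confirm this.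

Compound 4 is expected to give about 7500 nM, with a range of 3800 nM to 15000 nM, which corresponds to an estimated step of a 1.9-fold lower number from compound 3 to compound 4 (0.28 log units; within the scatter).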

Compound 4, half-maximal inhibitory concentration: 18600 nM
Beside the measured number, compound 4's estimate is 2.5-fold (0.39 log units) below it; measured number outside the range, above it.
By their numbers in this assay, from the lowest: compounds 1, 2, 3 and 4 (each within the scatter of the next, the first and the last beyond it).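

In this assay the change from hydrogen to methyl is a 1.3-fold higher number from compound 3 to compound 4 (0.11 log units; within the scatter) and so leaves no separable difference between the methyl and unsubstituted anilino rings. Methyl therefore does not reproduce the chloro effect at this position, which the earlier compounds could not show: replacing fluoro with methyl gives a 2.2-fold higher number from compound 2 to compound 4 (0.35 log units; beyond the scatter) and replacing chloro with methyl gives a 2.7-fold higher number from compound 1 to compound 4 (0.44 log units; beyond the scatter) and both steps lie beyond the scatter. Among the groups shown, a substituent at this position does not by itself lower the number, and what it lowers depends on the group, with both halogens standing apart from methyl. No supporting data bear on why methyl differs from chloro and fluoro here.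

Still open, on these data alone, is whether a bromo, methoxy or trifluoromethyl group at this position would track the halogens or methyl. The compounds shown also leave open how chloro and methyl would compare on another carbon of the anilino ring.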